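Dimethoxyphenyl for Phenyl on the Pyrazoline Core

This account rests on a few compounds, and the source may have more. Where it says the series, first, only, none or still open, it means among the compounds named here.

Of the compounds shown here, two from this series have been tested in a functional assay on COLO 205 cells (Homo sapiens) for inhibition, read by sulforhodamine B assay, tested at 10 uM; on this read-out lower numbers stand for less inhibition of growth and higher numbers for more inhibition of growth at the one concentration tested. Compound 1 `CC(=O)N1N=C(c2ccc(OCc3cn(Cc4ccc([N+](=O)[O-])cc4)nn3)cc2)CC1c1ccccc1` gives 18% in this assay. Compound 2 `COc1cc(C2CC(c3cccc4ccccc34)=NN2C(C)=O)ccc1OCc1cn(Cc2ccc([N+](=O)[O-])cc2)nn1` differs from compound 1 in several places. In this assay compound 2 gives 46%. Of the two numbers, compound 1 stands lowest, and the gap to compound 2 lies beyond the usual scatter of repeated measurements.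

Compound 3 `COc1ccc(C2CC(c3ccc(OCc4cn(Cc5ccc([N+](=O)[O-])cc5)nn4)cc3)=NN2C(C)=O)cc1OC` has not yet been measured. It is built from compound 1 by a single change: 3,4-dimethoxyphenyl in place of phenyl on a saturated ring carbon. For the measured compounds named here, no pair of measured compounds differs in this one place alone, so the data give no direct guide for the size of this step. The step from compound 1 to compound 3 is expected to be modest and upward, a number 10 percentage points higher from compound 1 to compound 3 (within the scatter), with a wide range allowed. Compound 3 is estimated to reach 28% in this assay, between 8% and 50%.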

Compound 3, percent growth inhibition at one concentration: 9%
Compound 3: middle estimate off by 19 percentage points, on the high side; low and high end bracket the measured number.
By their numbers in this assay, from the lowest: compounds 3 and 1 (each within the scatter of the next); then compound 2.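

In this assay, this position now has its first direct test, and the step is a number 9 percentage points lower from compound 1 to compound 3 (within the scatter). Compound 1 and compound 3 therefore cannot be told apart in this read-out, even though 3,4-dimethoxyphenyl brings more heavy atoms and two hydrogen-bond acceptors that phenyl lacks. Adding these two methoxy groups on the saturated ring carbon thus gives no clear gain or loss in growth inhibition at the one concentration tested, and no measurement shown here offers an explanation.

Still open, from the compounds shown here alone, is whether a different kind of group on this carbon, such as an amine or a carboxylic acid on the phenyl ring, would produce a step beyond the scatter. Going by these compounds, it is also open whether a single methoxy group would behave like the pair.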